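This account rests on a few compounds, and the source may have more. Where it says the series, first, only, none or still open, it means among the compounds named here.

Measured so far:
compound 1, `Cc1c(C(C)OC(=O)Nc2ccccc2)oc2nc(C3CC3)nn12` — 12.6 nM
compound 2, `Cc1nc2oc(C(C)OC(=O)Nc3ccccc3)c(C)n2n1` — 39.8 nM

Both numbers come from a functional assay on CHO cells for antagonist activity at metabotropic glutamate receptor 5 (Homo sapiens), read by calcium flux; a lower number here means a stronger inhibitor, a higher number a weaker inhibitor. Compound 2 stands at the higher of the two values; its nearest neighbour is compound 1, and the step of a 3.2-fold higher number from compound 1 to compound 2 (0.50 log units; beyond the scatter) lies beyond the scatter. The next compound, compound 3, `Cc1c(C(C)OC(=O)Nc2ccccc2)oc2nc(C(F)(F)F)nn12`, has not yet been measured in this assay. Against compound 2 the change is trifluoromethyl in place of methyl on an aromatic carbon. Going by the values given here, no measured step concerns a trifluoromethyl; the only step in hand at that place is a 3.2-fold higher number from compound 1 to compound 2 (0.50 log units; beyond the scatter), which swaps one small group for another and moved the number modestly. That step gives no direct guide to trifluoromethyl, so the expected step of a 1.6-fold lower number from compound 2 to compound 3 (0.20 log units; within the scatter) is small, if anything towards a lower number. Compound 3 is therefore estimated at 25 nM in this assay, with a range of 8 nM to 80 nM.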

Compound 3, half-maximal inhibitory concentration: 39.8 nM
The estimate for compound 3 lay 1.6-fold (0.20 log units) below the measured number; low and high end bracket the measured number.
By their numbers in this assay, from the lowest: compound 1; then compounds 2 and 3 (each within the scatter of the next).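

In this assay, the aromatic carbon between two ring nitrogen atoms accepts trifluoromethyl in place of methyl with no change at the digits printed from compound 2 to compound 3 (within the scatter), so going from 1 heavy atom to 4 in this group leaves the number unmoved here. Cyclopropyl keeps the lowest number of the three groups, with a 3.2-fold higher number from compound 1 to compound 3 (0.50 log units; beyond the scatter), which sets the methyl and trifluoromethyl compounds together apart from compound 1. No evidence in hand bears on this result.

Still open, going by these compounds, is whether the lower number is particular to cyclopropyl or would also extend to a cyclobutyl ring, an isopropyl group or a longer alkyl chain at this carbon. Also open, on these data alone, is how an amine or a methoxy group would read there, and the carbamate and its phenyl ring stay constant across all three compounds.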